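Notes on compound 3: an aryl exchange at the limit

The source may report more compounds than this note shows. Statements on the series, on what has been measured and on what is new or still open speak of the compounds shown alone.

- Compound 1 `CCOC(=O)/C=C/c1cc(/C=C/[C@](C)(/C=C/c2ccc(OC)cc2)CCC=C(C)C)ccc1O`: > 36600 nM (a limit)
- Compound 2 `COc1ccc(/C=C/[C@@](C)(/C=C/c2ccc(O)cc2)CCC=C(C)C)cc1`: > 36600 nM (a limit)
- Compound 3 `CC(C)=CCC[C@](C)(/C=C/c1ccc(O)cc1)/C=C/c1cccc(F)c1`: not yet measured

For the measured compounds named here, all readings come from a functional assay on SEM cells (Homo sapiens) for cytotoxicity, with a stated time of 72 h (a lower number here means that less compound is needed, a higher number that more compound is needed for the effect), and neither measured compound has a numerical value so far. In this assay compound 2 gives > 36600 nM and this is a limit, not a number. Going by the values given here, the series so far sits at one ceiling: the limit of > 36600 nM in this assay, at which 2 of the 2 values shown sit (no compound yet gives a number).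

Among the compounds with values here, the one measured step is a step that the two limits leave unreadable from compound 1 to compound 2 and it involves hydrogen in place of 2-(ethoxycarbonyl)ethenyl on an aromatic carbon. Its size cannot be read, and it concerns another part of the molecule.

Compound 3 differs from compound 2 as follows: 3-fluorophenyl in place of 4-methoxyphenyl on a double-bonded chain carbon bound to a double-bonded chain carbon. Within the data shown here, no measured step covers this exchange, so no size carries over to it.

In this assay the expected step is a step that the limit leaves unreadable from compound 2 to compound 3 and no direction is expected beyond the scatter. Another limit is the most likely report. Compound 3 is estimated at 40000 nM (expected range 15000 nM to 80000 nM).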

Compound 3, half-maximal effective concentration: > 36600 nM
Compound 3: no number, only a limit; the forecaster's own chance of this, stated with the estimate: 70%; the middle value lies beyond the limit too.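

In this assay compound 3 gives > 36600 nM as a limit and not a number. For the compounds shown here, compound 2 also has only a limit, so no step between compound 2 and compound 3 can be read. The compounds shown leave open whether any change on the shared core gives a numerical value in this assay at all.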